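This account rests on a few compounds, and the source may have more. Where it says the series, first, only, none or still open, it means among the compounds named here.

Measured compounds:
compound 1, `CC(C)CCn1ccc(-c2ccccc2)c(C#N)c1=O`, giving 135%
compound 2, `CC(C)CCn1ccc(N2CCCC(c3ccccc3)C2)c(C#N)c1=O`, giving 231%

In a functional assay on CHO cells for positive allosteric modulation of metabotropic glutamate receptor 2 (Homo sapiens), with a stated time of 30 min (a lower number here means a smaller maximal response, a higher number a larger maximal response), compound 2 stands highest of the two numbers available. Its nearest neighbour is compound 1, which gives 135%, a value lower by a margin that lies beyond the usual scatter of this assay. Compound 3, `CC(C)CCn1ccc(N2CCCCC2)c(C#N)c1=O`, has not yet been measured. It differs from compound 2 in one place: hydrogen in place of phenyl on a saturated ring carbon. Going by the values given here, no step between two measured compounds matches this change, so the expected size of the step rests only on the values of compound 2 and compound 1. Compound 3 is expected to move downward in this assay, by a step beyond the scatter, with the step of a number 81 percentage points lower from compound 2 to compound 3 (beyond the scatter) as the estimate. Compound 3 is therefore estimated at 150%, in a range from 90% to 220%, a figure that remains a rough expectation.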

Compound 3, largest response reached (Emax), in percent of the reference or control that the assay uses: 185%
Estimate against measurement, compound 3: 35 percentage points below; low and high end bracket the measured number.
By their numbers in this assay, from the lowest: compound 1; then compound 3; then compound 2.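

In this assay, taking the phenyl off the saturated ring carbon gives a number 46 percentage points lower from compound 2 to compound 3 (beyond the scatter) and so removes only part of the maximal response. Placing piperidin-1-yl instead of phenyl on the aromatic carbon gives a number 50 percentage points higher from compound 1 to compound 3 (beyond the scatter) even with no substituent on the saturated ring, so among these three compounds both the piperidin-1-yl and the phenyl it carries go with a higher maximal response, each by a step beyond the scatter. Nothing available explains either step.

The compounds shown leave open whether a methyl or a fluorine on the saturated ring carbon would also raise the response over that of compound 3. Going by these compounds, it also remains open whether a morpholin-4-yl in place of piperidin-1-yl on the aromatic carbon would hold the response.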